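A Fluoro Step on the Benzyl of Compound 2

A few compounds are considered here, and "the series" means these few. Any claim that something is new, unique, unknown or untested is made for them only; others in the source may bear on it.

Values so far in a functional assay, read by spectrophotometry, with a stated time of 30 min (a lower number here means a stronger inhibitor, a higher number a weaker inhibitor), are these:
- Compound 1 `CC(C)(C)c1cc(/C=C/C(=O)NCC2CCN(Cc3ccccc3)CC2)cc(C(C)(C)C)c1O` gives 75600 nM
- Compound 2 `CC(C)(C)c1cc(/C=C/C(=O)NCCC2CCN(Cc3ccccc3)CC2)cc(C(C)(C)C)c1O` gives 81700 nM

Compound 2 at 81700 nM and compound 1 at 75600 nM lie within the scatter of each other, so the two cannot be ranked. Among the measured compounds shown here, compound 2 therefore stands level with the only other measured compound, and these two values are all there is to go on.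

Compound 3 `CC(C)(C)c1cc(/C=C/C(=O)NCCC2CCN(Cc3ccccc3F)CC2)cc(C(C)(C)C)c1O` departs from compound 2 by fluoro in place of hydrogen on an aromatic carbon and so carries fluoro in place of hydrogen on an aromatic carbon, turning benzyl into 2-fluorobenzyl. For the measured compounds named here, no measured pair shows what such a change does. In this assay no step beyond the scatter is therefore expected, with only a slight lean towards a lower number, which would mean a stronger inhibitor. The expected move is a 1.4-fold lower number from compound 2 to compound 3 (0.13 log units; within the scatter) and it should stay small. Compound 3 is estimated at 60000 nM with an expected range from 25000 nM to 120000 nM when it is measured.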

Compound 3, half-maximal inhibitory concentration: 55900 nM
For compound 3 the middle estimate is 1.1-fold (0.03 log units) above the measured one; the range from low to high includes it.
By their numbers in this assay, from the lowest: compounds 3, 1 and 2 (each within the scatter of the next).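

Among the compounds shown here, this step is the first measured change at the benzyl end of the series, as the earlier pair differed only in the chain on the amide nitrogen. In this assay, turning benzyl into 2-fluorobenzyl gives a 1.5-fold lower number from compound 2 to compound 3 (0.16 log units; within the scatter), so a single fluoro on an aromatic carbon, ortho to a large group, produces no change that can be told from the usual scatter. What the pair establishes is therefore limited: this carbon accepts fluoro in place of hydrogen with compound 3 remaining level with compound 2, and the series gains no clear separation from this replacement. No supporting measurement bears on this result, so it stands without an explanation.

The compounds shown leave open whether a larger group at the same carbon, such as chloro, methoxy, trifluoromethyl or nitrile, would give a step beyond the scatter, since fluoro adds only one heavy atom. They also leave open whether an amine or a carboxylic acid on the benzyl, or a longer chain on the amide nitrogen, would move the number more clearly than this replacement did.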